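The compounds below may be only part of what the source reports. "The series", "measured", "known", "first", "only" and "open" are said of these compounds alone.

Measured so far:
compound 1 `CCn1c(C(=O)N(CCC#N)CCC#N)ccc1C(CC)(CC)c1ccc(OCC(O)C(C)(C)C)c(C)c1` — 97 nM in an assay on HL-60 cells for agonist activity at vitamin D3 receptor (Homo sapiens), read by microscopy, with a stated time of 96 h; a lower number here means that less compound is needed, a higher number that more compound is needed for the effect
compound 2 `C#CC(C)OC(=O)c1ccc(C(CC)(CC)c2ccc(OCC(O)C(C)(C)C)c(C)c2)n1CC` — 200 nM in this assay

On the two numbers in hand, compound 2 stands highest; its nearest neighbour is compound 1, whose value is 97 nM, so compound 2 sits at the top of a short pair. The step from compound 1 to compound 2 is a 2.1-fold higher number from compound 1 to compound 2 (0.31 log units; beyond the scatter): an ester in place of an amide on the carbonyl carbon raised the number by a modest amount beyond the scatter.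

Compound 3 `CC[C@@H](C)[C@H](NC(=O)c1ccc(C(CC)(CC)c2ccc(OCC(O)C(C)(C)C)c(C)c2)n1CC)C(=O)O` is not yet measured. It differs from compound 2 in one place: (1-carboxy-2-methylbutyl)amino in place of (1-methylprop-2-yn-1-yl)oxy on a carbonyl carbon. Going by the values given here, this reverses the direction of the only step on record, returning to an amide on the carbonyl carbon attached to the aromatic carbon, though with a different substituent on the nitrogen than compound 1 carries.

Among the compounds with values here, only the step from compound 1 to compound 2 bears on this change, and it was modest. The expected step from compound 2 to compound 3 is therefore a 1.3-fold lower number from compound 2 to compound 3 (0.12 log units; within the scatter), a modest fall. Compound 3 is estimated at 150 nM, with a range from 50 nM to 500 nM.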

Compound 3, half-maximal effective concentration: 2.3 nM
Compound 3: middle estimate off by 65-fold (1.81 log units), on the high side; measured number outside the range, below it.
By their numbers in this assay, from the lowest: compound 3; then compound 1; then compound 2.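

In this assay, (1-carboxy-2-methylbutyl)amino in place of (1-methylprop-2-yn-1-yl)oxy on this carbonyl carbon gives a far larger step than the earlier pair showed (an 87-fold lower number from compound 2 to compound 3 (1.94 log units; beyond the scatter)). The comparison with compound 1, also an amide on this carbonyl carbon, gives a step of similar order (a 42-fold lower number from compound 1 to compound 3 (1.63 log units; beyond the scatter)), so the amide alone does not set the number here; the group on the nitrogen changes it strongly. No measurement at hand accounts for the size of either step.

As far as these compounds go, it remains open whether the gain belongs to the carboxylic acid, to the rest of the chain or to the two defined stereocentres. The methyl ester of this acid and the opposite configuration at those stereocentres would tell these apart.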